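The source may report more compounds than this note shows. Statements on the series, on what has been measured and on what is new or still open speak of the compounds shown alone.

In an ADME assay on BHK-21 cells (Mesocricetus auratus) for cytotoxicity, read by MTT assay, with a stated time of 72 h (on this read-out higher numbers stand for lower toxicity in this test and lower numbers for higher toxicity in this test), compound 1 (`Cc1ccccc1C1CC(c2ccc(OCc3ccccc3)cc2)=NN1c1ccc(S(N)(=O)=O)cc1`) gives 20000 nM while compound 2 (`NS(=O)(=O)c1ccc(N2N=C(c3ccc(Oc4ccccc4)cc3)CC2c2cccc(F)c2)cc1`) gives 10000 nM and compound 3 (`NS(=O)(=O)c1ccc(N2N=C(c3ccc(Oc4ccccc4)cc3)CC2c2cccc(Cl)c2)cc1`) gives 9000 nM as its reading. Compound 3 therefore stands level with compound 2 within the scatter, and its number lies under that of compound 1 by more than the scatter.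

Compound 4 (`Cc1ccccc1C1CC(c2ccc(Oc3ccccc3)cc2)=NN1c1ccc(S(N)(=O)=O)cc1`) is still unmeasured. It carries 2-methylphenyl in place of 3-chlorophenyl on a saturated ring carbon and otherwise matches compound 3.

Among the measured compounds shown here, the only measured step in one place, chloro in place of fluoro, is a 1.1-fold lower number from compound 2 to compound 3 (0.05 log units; within the scatter) and so shows no sizeable move for that one swap. It does not cover a change to 2-methylphenyl. For the measured compounds named here, compound 1 is the only measured compound with the 2-methylphenyl group, at 20000 nM in this series, but it also differs from compound 4 elsewhere, so no measured step isolates the swap. Its value supports expecting a small rise at most, and no move beyond the scatter is expected in this assay overall. The expected step is a 1.3-fold higher number from compound 3 to compound 4 (0.12 log units; within the scatter) on this reasoning. For compound 4 the estimate is 12000 nM with an expected range from 6000 nM to 25000 nM in this assay.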

Compound 4, half-maximal cytotoxic concentration: 7000 nM
Beside the measured number, compound 4's estimate is 1.7-fold (0.23 log units) above it; the range from low to high includes it.
By their numbers in this assay, from the lowest: compounds 4, 3, 2 and 1 (each within the scatter of the next, the first and the last beyond it).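

In this assay the group on the saturated ring carbon, next to the ring nitrogen, now has measured steps in one place: 2-methylphenyl against 3-chlorophenyl (a 1.3-fold lower number from compound 3 to compound 4 (0.11 log units; within the scatter)) and 2-methylphenyl against 3-fluorophenyl (a 1.4-fold lower number from compound 2 to compound 4 (0.15 log units; within the scatter)). Both lie within the scatter, so these three aryl groups read alike at this position on the shared core, and the 2-methyl pattern is now separated from the change at the other end of the molecule. Among the compounds shown here, with 2-methylphenyl held constant, phenyl in place of benzyl on the oxygen on an aromatic ring gives the only new step beyond the scatter, a modest one (a 2.9-fold lower number from compound 1 to compound 4 (0.46 log units; beyond the scatter)), and no measurement on these compounds accounts for it. The compounds shown leave open whether a group of another kind on the saturated ring carbon, such as cyclohexyl, pyridyl, or a phenyl carrying an amine or a carboxylic acid, would move the reading beyond the scatter. They also leave open whether the step from benzyl to phenyl holds with 3-chlorophenyl or 3-fluorophenyl in place, and how a longer chain on that oxygen would read.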